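Trimming the Ester Chain of Compound 1

The source may report more compounds than this note shows. Statements on the series, on what has been measured and on what is new or still open speak of the compounds shown alone.

Compound 1 `CCCCOC(=O)c1cccc(-c2cc(C(=O)Nc3ccncc3)ccc2CN)c1` carries a butyl ester on one of its aryl rings. In an assay on isolated protein for inhibition of Rho-associated protein kinase 2 (Homo sapiens), read by radiometric assay (on this read-out higher numbers stand for weaker inhibition and lower numbers for stronger inhibition), compound 1 gives 5.5 nM, the highest of the three numbers recorded. Compound 2 `NCc1ccc(C(=O)Nc2ccncc2F)cc1-c1cccc(C(=O)OCC2CC2)c1` gives 2.7 nM and compound 3 `NCc1ccc(C(=O)Nc2ccncc2F)cc1-c1cccc(C(=O)OCC2CCCO2)c1` gives 2.5 nM; both differ from compound 1 in more than one place, so their values are only a backdrop, though each sits beyond the scatter from compound 1. Within the data shown here, the single one-place step among the measured compounds is a 1.1-fold lower number from compound 2 to compound 3 (0.03 log units; within the scatter), showing that swapping one saturated ring for another at the ester chain end leaves the number essentially unchanged.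

Compound 4 `COC(=O)c1cccc(-c2cc(C(=O)Nc3ccncc3)ccc2CN)c1` is the next step from compound 1: hydrogen in place of propyl on a saturated chain carbon bound to an oxygen next to a carbonyl group. Among the measured compounds shown here, no measured step removes carbons from this chain outright; the only nearby precedent, the step from compound 2 to compound 3, merely exchanges ring types and stays within the scatter. The ester substituent therefore appears tolerant, and a change no larger than the scatter, perhaps a slightly higher number for compound 4, is the reasonable expectation. The expected step is a 1.5-fold higher number from compound 1 to compound 4 (0.16 log units; within the scatter). Compound 4 is thus estimated to give 8 nM, within the range 3 nM to 22 nM.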

Compound 4, half-maximal inhibitory concentration: 2.9 nM
Compound 4: the middle estimate sits 2.8-fold (0.44 log units) above what was measured; the whole stated range lies above it.
By their numbers in this assay, from the lowest: compounds 3, 2, 4 and 1 (each within the scatter of the next, the first and the last beyond it).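

With the shared core left unchanged, going from butoxycarbonyl to methoxycarbonyl gives a 1.9-fold lower number from compound 1 to compound 4 (0.28 log units; within the scatter) in this assay, so the two compounds cannot be told apart on this read-out. Among these compounds, this is the first direct look at chain length at this ester: the earlier step, a 1.1-fold lower number from compound 2 to compound 3 (0.03 log units; within the scatter), only exchanged one ring-bearing chain end for another, whereas here propyl gives way to hydrogen on the saturated chain carbon bound to the oxygen next to the carbonyl group. Among the compounds shown, therefore, the butyl chain can be cut back to methyl with no step beyond the scatter, which means that the outer part of the butyl chain is not needed to keep the number in the low nanomolar range seen for compound 1 and compound 4.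

Nothing available explains why the shorter chain reads as it does.

Still open, from the compounds shown here alone, is whether the position would accept a carboxylic acid or a primary amide in place of the ester, or a chain longer than butyl. Going by these compounds, it is equally open whether a methyl ester on the core of compound 2 would read like the cyclopropylmethyl ester of compound 2 itself.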